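Removing the ethyl from the piperazine of compound 1

The source may report more compounds than this note shows. Statements on the series, on what has been measured and on what is new or still open speak of the compounds shown alone.

Of the compounds shown here, three have been measured in a functional assay on NCI-H1581 cells (Homo sapiens) for antiproliferative activity, read by CCK-8 assay, with a stated time of 72 h; on this read-out lower numbers stand for stronger inhibition and higher numbers for weaker inhibition. Compound 1 `CCN1CCN(c2ccc(C(=O)Nc3n[nH]c4nc(-c5c(Cl)c(OC)cc(OC)c5Cl)ccc34)cc2)CC1` gives 0.7 nM in this assay, the lowest of the three numbers. Its nearest neighbour is compound 2 `COc1cc(OC)c(Cl)c(-c2ccc3c(NC(=O)c4ccc(N5CCN(C)CC5)nc4)n[nH]c3n2)c1Cl`, which gives 1.5 nM in this assay, a gap beyond the usual scatter, and furthest from it lies compound 3 `COc1cc(OC)c(Cl)c(-c2ccc3c(NC(=O)c4ccc(N5CCN(C)CC5)cn4)n[nH]c3n2)c1Cl`, which gives 4.4 nM in this assay. No two of these compounds differ in only one place, so no single step between measured compounds can be read from them.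

The unmeasured compound 4 `COc1cc(OC)c(Cl)c(-c2ccc3c(NC(=O)c4ccc(N5CCNCC5)cc4)n[nH]c3n2)c1Cl` shares the core of compound 1 and departs from it in one place: hydrogen in place of ethyl on an amine nitrogen in a ring. Read one bond further out, a 4-ethylpiperazin-1-yl becomes a piperazin-1-yl. Going by the values given here, nothing among the measured compounds shows what this exchange does in this assay, so the expectation rests on the small size of the change, which removes an ethyl of two carbon atoms and brings in a hydrogen.

For compound 4 the expected step of a 1.7-fold higher number from compound 1 to compound 4 (0.23 log units; within the scatter) is small, if anything toward a slightly higher number, and is not expected to exceed the scatter. Compound 4 is therefore estimated at 1.2 nM in this assay, within a range from 0.4 nM to 4 nM.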

Compound 4, half-maximal inhibitory concentration: 1.4 nM
Compound 4: the middle estimate sits 1.2-fold (0.07 log units) below what was measured, within the range that was stated.
By their numbers in this assay, from the lowest: compounds 1, 4 and 2 (each within the scatter of the next, the first and the last beyond it); then compound 3.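

Going by these compounds alone, the exchange of ethyl for hydrogen on this amine nitrogen in a ring gives the first step between compounds that differ in one place: in this assay it is a 2.0-fold higher number from compound 1 to compound 4 (0.30 log units; within the scatter). At this position, then, the two carbon atoms of the ethyl can leave without a difference beyond the scatter, and the 4-ethylpiperazin-1-yl and the piperazin-1-yl cannot be told apart on this read-out. No measurement at hand speaks to the reason for this result.

As far as these compounds go, what remains open is whether a longer chain such as propyl, a 2-hydroxyethyl or an acetyl on this nitrogen would also lie within the scatter of compound 1 in this assay, or would move the number beyond it. Also open, from the compounds shown here alone, is whether hydrogen in place of the methyl on the corresponding nitrogen of compound 2 or compound 3 would give a step as small as this one.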